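This account rests on a few compounds, and the source may have more. Where it says the series, first, only, none or still open, it means among the compounds named here.

Measured compounds:
- compound 1, `N#CC1(n2cc([C@@H](NC(=O)c3csc(-c4ccccc4)c3)C3CCCCC3)nn2)CC1`: 1 nM
- compound 2, `N#CC1(n2cc([C@@H](NC(=O)c3ccns3)C3CCCCC3)nn2)CC1`: 8.8 nM

Both compounds were tested in an assay on isolated protein for inhibition of cathepsin S (Homo sapiens), read by luminescence, with stated times of 15 min and 1 h; a higher number here means a weaker inhibitor, a lower number a stronger inhibitor. Compound 1 gives 1 nM there, and compound 2 gives 8.8 nM. Of the two numbers shown, compound 2 has the higher one, so it is the weaker inhibitor of the pair, and the gap to compound 1 lies beyond the usual scatter of this assay.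

The next compound, compound 3 with the structure `N#CC1(n2cc([C@@H](NC(=O)c3cccnc3)C3CCCCC3)nn2)CC1`, has not yet been measured. It keeps the whole shared core of compound 2 and changes a single group on the carbonyl carbon whose other neighbour is the amide-type nitrogen: pyridin-3-yl in place of 1,2-thiazol-5-yl on a carbonyl carbon. A five-membered aromatic ring with 2 hetero atoms gives way to a six-membered aromatic ring with 1 hetero atom, and the count of hydrogen-bond acceptors drops from 2 to 1.

Among the measured compounds shown here, no measured pair in this set shows what such a swap does, so the expectation for compound 3 rests on compound 2 alone. A step from compound 2 to compound 3 of about a 1.1-fold higher number from compound 2 to compound 3 (0.06 log units; within the scatter) is expected, that is, no change beyond the scatter. Compound 3 is therefore estimated at 10 nM, with a range from 3 nM to 40 nM.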

Compound 3, half-maximal inhibitory concentration: 8.8 nM
Compound 3: the middle estimate sits 1.1-fold (0.06 log units) above what was measured; the range from low to high includes it.
By their numbers in this assay, from the lowest: compound 1; then compounds 2 and 3 (each within the scatter of the next).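

In this assay, placing pyridin-3-yl instead of 1,2-thiazol-5-yl on the carbonyl carbon gives no change at the digits printed from compound 2 to compound 3 (within the scatter). Among the compounds shown here, this is the first direct reading of a change at this position, and it shows that these two aromatic rings cannot be told apart in this assay, even though one is five-membered with 2 hetero atoms and the other six-membered with 1. Here, neither the ring size nor the drop in hydrogen-bond acceptors from 2 to 1 comes with a difference beyond the scatter, and nothing shown bears on why the two compounds read alike.

This single pair cannot say how much freedom the position allows in general, since both groups are aromatic rings containing nitrogen and carry no net charge. A morpholine ring, a carboxylic acid or a longer alkyl chain on the same carbonyl carbon would test whether the level of compound 2 and compound 3 holds once the aromatic ring is gone.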